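Swapping Fluoro for Cyano in a Poorly Soluble Compound

The compounds below may be only part of what the source reports. "The series", "measured", "known", "first", "only" and "open" are said of these compounds alone.

Compound 1 `Cc1c(Cc2ccc(F)cc2)c(=O)oc2cc(OCCOc3no[n+]([O-])c3S(=O)(=O)c3ccccc3)ccc12` holds the lowest of the two solubility numbers measured: in a physicochemical assay for solubility, read by HPLC, in phosphate buffer, with a stated time of 24 h (a higher number here means a more soluble compound, a lower number a less soluble compound), compound 1 gives 0.01 ug/mL, while compound 2 `COc1cc(OCCOc2no[n+]([O-])c2S(=O)(=O)c2ccccc2)ccc1C(=O)N/N=C/c1ccc(F)cc1` gives 1.3 ug/mL, a gap far beyond the usual scatter. Compound 3 `Cc1c(Cc2ccc(C#N)cc2)c(=O)oc2cc(OCCOc3no[n+]([O-])c3S(=O)(=O)c3ccccc3)ccc12` differs from compound 1 in a single place: cyano in place of fluoro on an aromatic carbon. Among the measured compounds shown here, no measured pair shows this change, so its size is not known from the data; the step is expected to be small, a 2.0-fold higher number from compound 1 to compound 3 (0.30 log units; within the scatter), leaning toward a somewhat higher number but quite possibly within the scatter. Compound 3 is therefore estimated at 0.02 ug/mL, with a likely range from 0.005 ug/mL to 0.1 ug/mL.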

Compound 3, solubility: 7.3 ug/mL
The estimate for compound 3 lay 370-fold (2.56 log units) below the measured number; the measured number lies above the stated range.
By their numbers in this assay, from the lowest: compound 1; then compound 2; then compound 3.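

Among the compounds shown here, putting cyano in place of fluoro on this aromatic carbon gives a 730-fold higher number from compound 1 to compound 3 (2.86 log units; beyond the scatter) in this assay and so shows that a change of one small group at this place can move the number by a large step, which the earlier compounds could not show. Nothing available bears on why the number rose so far.

Still open, from the compounds shown here alone, is how an amine or a carboxylic acid at the same place would compare with cyano. Also open, going by these compounds, is whether the same swap gives a step of this size on a different core.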